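A few compounds are considered here, and "the series" means these few. Any claim that something is new, unique, unknown or untested is made for them only; others in the source may bear on it.

Measured in a functional assay on K562 cells (Homo sapiens) for inhibition, read by sulforhodamine B assay, with a stated time of 48 h; a higher number here means a weaker inhibitor of growth, a lower number a stronger inhibitor of growth:
Compound 1 `CC1=CC[C@H](C(C)(C)NC(=S)N/N=C/c2ccccc2)CC1` gives 47600 nM.
Compound 2 `CC1=CC[C@H](C(C)(C)NC(=S)N/N=C/c2ccccc2O)CC1` gives only a limit, > 100000 nM.
Compound 3 `CC1=CC[C@H](C(C)(C)NC(=S)N/N=C/c2ccccc2Cl)CC1` gives 66200 nM.

Compound 3 and compound 1 lie within the scatter of each other, a 1.4-fold higher number from compound 1 to compound 3 (0.14 log units; within the scatter). Compound 2 is a limit, not a number.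

Compound 4 `CC1=CC[C@H](C(C)(C)NC(=S)N/N=C/c2ccccc2[N+](=O)[O-])CC1` differs from compound 3 by nitro in place of chloro on an aromatic carbon. The steps at this aromatic carbon bear on it: chloro for hydrogen, a 1.4-fold higher number from compound 1 to compound 3 (0.14 log units; within the scatter); hydroxy for hydrogen, an at least 2.1-fold higher number from compound 1 to compound 2 (0.32 log units; beyond the scatter); chloro for hydroxy, an at least 1.5-fold lower number from compound 2 to compound 3 (0.17 log units; that floor lies within the scatter). Only the hydroxy step moved beyond the scatter, and it did so toward weaker growth inhibition. Among the compounds with values here, no nitro analogue is measured. For compound 4 in this assay the expected step is a 1.2-fold higher number from compound 3 to compound 4 (0.08 log units; within the scatter), at most a small rise. The estimate for compound 4 is 80000 nM, range 40000 nM to 160000 nM.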

Compound 4, concentration for total growth inhibition: > 100000 nM
Compound 4: no number, only a limit; the forecaster's own chance of this, stated with the estimate: 35%; middle value at least 1.2-fold (0.09 log units) away from the limit.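

In this assay compound 4 gives only a limit, not a number, and nitro joins hydroxy as a group at this aromatic carbon that ends there: the limit of > 100000 nM in this assay, at which 2 of the 4 values shown sit. Against hydrogen the change is an at least 2.1-fold higher number from compound 1 to compound 4 (0.32 log units; beyond the scatter), so two groups, hydroxy and nitro, now pass the scatter toward weaker growth inhibition, while chloro in compound 3 does not. Against chloro it is an at least 1.5-fold higher number from compound 3 to compound 4 (0.17 log units; that floor lies within the scatter), which does not separate compound 4 from compound 3.

The step between compound 2 and compound 4 cannot be read, since both are limits. From the compounds shown here alone, whether an amine or a methoxy group at this carbon would give a measurable number remains open.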